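A few compounds are considered here, and "the series" means these few. Any claim that something is new, unique, unknown or untested is made for them only; others in the source may bear on it.

Of the compounds shown here, three have been tested in an assay on nucleic acid for inhibition of Nucleic Acid, read by fluorescence, tested at 100 uM; a higher number here means more inhibition at the concentration tested (going by the name of the read-out), a lower number less inhibition. Compound 1, `CN(CCCc1ccccc1)Cc1cn(CC(O)COC(=O)NCc2ccccc2)nn1`, gives 79%. Compound 2, `CC(C)CCN(C)Cc1cn(CC(O)COC(=O)NCc2ccccc2)nn1`, gives 26%. Compound 3, `CCCCC(O)Cn1cc(CN(C)CCC(C)C)nn1`, gives 47%, and its core is not the same as that of compound 2; the difference between the two cores is not broken down here.

Compounds 1 and 2 differ in one place only, namely (benzyl in place of isopropyl on a saturated chain carbon, two bonds along the chain from an amine nitrogen). That single change made a number 53 percentage points higher from compound 2 to compound 1 (beyond the scatter), a move well beyond the usual scatter of the assay.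

Compound 4, `CCCCC(O)Cn1cc(CN(C)CCCc2ccccc2)nn1`, has not yet been measured. Compared with compound 3 it carries the same change, (benzyl in place of isopropyl on a saturated chain carbon, two bonds along the chain from an amine nitrogen), sitting at the same kind of position as in the earlier pair. A step of about a number 38 percentage points higher from compound 3 to compound 4 (beyond the scatter) is expected in this assay, somewhat smaller than the earlier one, because compound 3 already starts at 47%, a higher number than the starting point of the earlier pair, and because the earlier pair gave a number 53 percentage points higher from compound 2 to compound 1 (beyond the scatter) on a different core. Compound 4 is therefore expected to give around 85%, most likely between 65% and 100%.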

Compound 4, a percentage reported as inhibition, at one concentration (the size of the read-out at that concentration, not a potency): 37%
Compound 4: middle estimate off by 48 percentage points, on the high side, and the stated range ends above it.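

In this assay, benzyl in place of isopropyl gave a number 10 percentage points lower from compound 3 to compound 4 (within the scatter), a step that cannot be told apart from no change at all. Set beside the earlier pair, the same change clearly did not carry over from one core to the other: the same change on two cores in this assay, a number 53 percentage points higher (beyond the scatter) from compound 2 to compound 1 and a number 10 percentage points lower (within the scatter) from compound 3 to compound 4, 63 percentage points apart, beyond the scatter of two such steps This does not show why the two cores part ways, and with only two pairs it cannot say which result is typical of this change or what it would do on a third core.

The compounds shown leave open which part of the core of compound 1 goes with the large step seen there, since the two cores differ and that difference is not broken down. Also open, as far as these compounds go, is how a cyclohexyl group or a longer alkyl chain would read on each core, on a saturated chain carbon, two bonds along the chain from an amine nitrogen.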